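Swapping Trifluoromethyl for Bromo on the Fused Ring

The compounds below may be only part of what the source reports. "The series", "measured", "known", "first", "only" and "open" are said of these compounds alone.

Among the compounds with values here, compound 3 `Fc1cc(Cl)ccc1-c1ccc(Cn2nnc3c(C(F)(F)F)cccc32)cn1` gives 13 nM in a functional assay on cells for positive allosteric modulation of metabotropic glutamate receptor 2 (Homo sapiens), read by fluorescence and calcium flux, with a stated time of 30 min (a higher number here means that more compound is needed for the effect, a lower number that less compound is needed), the lowest of the three numbers measured so far. Compound 1 `Fc1cc(Cl)ccc1-c1ccc(Cn2nnc3c(F)cccc32)cn1` gives 27 nM, and compound 2 `N#Cc1cccc2c1nnn2Cc1ccc(-c2ccc(Cl)cc2F)nc1` gives 33 nM. Compound 4 `Fc1cc(Cl)ccc1-c1ccc(Cn2nnc3c(Br)cccc32)cn1` carries a change at the same place: bromo in place of trifluoromethyl on an aromatic carbon. Within the data shown here, two measured steps bear on this position, a 2.1-fold lower number from compound 1 to compound 3 (0.32 log units; beyond the scatter) and a 2.5-fold lower number from compound 2 to compound 3 (0.40 log units; beyond the scatter), so both changes into trifluoromethyl lowered the number modestly, and a change out of it is expected to raise it; the step of a 1.2-fold higher number from compound 1 to compound 2 (0.09 log units; within the scatter) shows that two other groups here sit close together. Compound 4 is therefore expected to give back part of the gain of compound 3, with an estimated step of a 1.7-fold higher number from compound 3 to compound 4 (0.23 log units; within the scatter). The estimate for compound 4 is 22 nM, ranging from 9 nM to 55 nM.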

Compound 4, half-maximal effective concentration: 6 nM
Compound 4: middle estimate off by 3.7-fold (0.56 log units), on the high side, outside the stated range (below it).
By their numbers in this assay, from the lowest: compound 4; then compound 3; then compounds 1 and 2 (each within the scatter of the next).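

Trifluoromethyl is not the best group shown on this aromatic carbon: in this assay bromo gives a 2.2-fold lower number from compound 3 to compound 4 (0.34 log units; beyond the scatter) and so lowers the number further. Bromo also improves on the other two groups, with a 4.5-fold lower number from compound 1 to compound 4 (0.65 log units; beyond the scatter) and a 5.5-fold lower number from compound 2 to compound 4 (0.74 log units; beyond the scatter) in the same assay. A single bromine atom therefore does better here than the four heavy atoms of trifluoromethyl. Nothing available explains why bromo gives the lowest number.

From the compounds shown here alone, whether chloro or iodo would lower the number further remains open, as does how a methyl or an amine on this carbon would compare.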